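Dropping the 2-methoxyphenyl from compound 3

The source may report more compounds than this note shows. Statements on the series, on what has been measured and on what is new or still open speak of the compounds shown alone.

Measured in a functional assay on cells (T-cell line, Homo sapiens) for inhibition; on this read-out lower numbers stand for stronger inhibition and higher numbers for weaker inhibition:
- compound 1 `COc1ccc(CCCN2CCC(COCc3ccccn3)CC2)cc1`: 5900 nM
- compound 2 `COc1ccc(CCCN2CCC(COC(c3ccccc3)c3ccc(Cl)cc3)CC2)cc1`: 200 nM
- compound 3 `COc1ccccc1CCCN1CCC(COC(c2ccccc2)c2ccccc2)CC1`: 2400 nM

Compound 3 holds the middle place among these three numbers. Compound 1 stands above it, and compound 2 stands well below it, both gaps lying beyond the scatter. The three compounds differ in more than one place, so none of these gaps isolates a single structural change.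

Compound 4 `CCCCN1CCC(COC(c2ccccc2)c2ccccc2)CC1` has not yet been measured in this assay. It carries methyl in place of 2-methoxyphenyl on a saturated chain carbon, three bonds along the chain from an amine nitrogen in a ring. Among the compounds with values here, no measured pair shows what this change does on its own, so any forecast is uncertain. All three measured compounds keep a methoxyphenyl group on their chain, and compound 4 would be the first without one. The forecast starts from compound 3 at 2400 nM, which still holds the group that compound 4 loses. A moderate move toward weaker inhibition is expected, with the estimated step being a 2.5-fold higher number from compound 3 to compound 4 (0.40 log units; beyond the scatter), although a result within the scatter would not be surprising. For compound 4 the expected value is 6000 nM, with an estimated range from 1800 nM to 20000 nM.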

Compound 4, half-maximal inhibitory concentration: 14000 nM
Compound 4: the middle estimate sits 2.3-fold (0.37 log units) below what was measured; the range from low to high includes it.
By their numbers in this assay, from the lowest: compound 2; then compound 3; then compound 1; then compound 4.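

Within the data shown here, the result gives the first reading of a single change at this position: in this assay, methyl in place of 2-methoxyphenyl on a saturated chain carbon, three bonds along the chain from an amine nitrogen in a ring, brings a 5.8-fold higher number from compound 3 to compound 4 (0.77 log units; beyond the scatter). The 2-methoxyphenyl therefore contributes to inhibition on this scaffold, though it is not required for a number to be read, since compound 4, with no ring left on that chain, still gives 14000 nM. Nothing available bears on why inhibition weakens with this change.

The compounds shown leave open whether the step follows the loss of the aromatic ring, the loss of the methoxy group or the shortening of the chain, and a plain phenyl or a longer chain such as hexyl at the same place, with the rest of compound 3 unchanged, would begin to separate these. Compounds 1 and 2 cannot settle this, as each differs from compound 3 and compound 4 in more than one place, so their gaps to those two cannot be read as the effect of any single change.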